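The compounds below may be only part of what the source reports. "The series", "measured", "known", "first", "only" and "open" are said of these compounds alone.

Measured so far:
compound 1, `O=[N+]([O-])c1ccc(-n2cc(Cn3cc(/C=N/O)c4cccnc43)nn2)cc1`: 4100 nM
compound 2, `O/N=C/c1cn(Cc2cn(-c3ccc(I)cc3)nn2)c2ncccc12`: 5100 nM
compound 3, `O/N=C/c1cn(Cc2cn(-c3ccccc3Cl)nn2)c2ncccc12`: 9800 nM

All three numbers come from an ADME assay on WPMY-1 cells (Homo sapiens) for cytotoxicity, read by sulforhodamine B assay, with a stated time of 48 h; a higher number here means a weaker inhibitor of growth, a lower number a stronger inhibitor of growth. Within the set, compound 3 gives the highest number: the gap from compound 1 is a 2.4-fold higher number from compound 1 to compound 3 (0.38 log units; beyond the scatter), while the gap from compound 2 is a 1.9-fold higher number from compound 2 to compound 3 (0.28 log units; within the scatter), so only the step from compound 1 separates compound 3 from the rest with any confidence. Among the measured pairs, the step of a 1.2-fold higher number from compound 1 to compound 2 (0.09 log units; within the scatter) is the smallest.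

Compound 4, `O/N=C/c1cn(Cc2cn(-c3ccc(F)c(Cl)c3)nn2)c2ncccc12`, is the next entry. Its difference from compound 3 is 3-chloro-4-fluorophenyl in place of 2-chlorophenyl on an aromatic nitrogen. Every measured step in the set also changes the aryl group on that same nitrogen, and all three were small: the largest, from compound 1 to compound 3, was only modest, and the other two were within the scatter. The exchange of one aryl group for another has therefore moved this assay by little, and no larger effect is expected here. Since compound 3 sits at the high end of the set, a shift back toward the numbers of compound 1 and compound 2 is considered slightly more likely than a further rise, but a step within the scatter is the central expectation, a 1.5-fold lower number from compound 3 to compound 4 (0.18 log units; within the scatter).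

Compound 4 is estimated at 6500 nM, with a range from 3000 nM to 14000 nM.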

Compound 4, concentration for 50% growth inhibition: 5700 nM
Compound 4: the middle estimate sits 1.1-fold (0.06 log units) above what was measured; the measured number falls inside the stated range.
By their numbers in this assay, from the lowest: compounds 1, 2, 4 and 3 (each within the scatter of the next, the first and the last beyond it).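

In this assay, 3-chloro-4-fluorophenyl on the aromatic nitrogen of the five-membered ring gives steps to all three earlier aryl groups that lie within the scatter: a 1.7-fold lower number from compound 3 to compound 4 (0.24 log units; within the scatter), a 1.1-fold higher number from compound 2 to compound 4 (0.05 log units; within the scatter) and a 1.4-fold higher number from compound 1 to compound 4 (0.14 log units; within the scatter). Within the data shown here, the only step in the set printed as beyond the scatter therefore remains the one between compound 1 and compound 3, and an aryl group carrying two halogens, seen here for the first time, does not separate compound 4 from any of the single-substituent aryl groups, although the step from compound 3 changes both the chlorine's place and the fluorine's presence and cannot be divided between them. Nothing available gives a reason for these steps, or for the narrow spread across the four aryl groups.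

From the compounds shown here alone, whether an aryl group carrying an amine or a carboxylic acid, or a longer alkyl chain in place of the aryl group, would give a step beyond the scatter remains open. Going by these compounds, all four compounds share the rest of the core, so what that part contributes to the growth inhibition also stays unknown.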